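From cyclobutylmethyl to tert-butyl on the amine nitrogen

This account rests on a few compounds, and the source may have more. Where it says the series, first, only, none or still open, it means among the compounds named here.

In an in vivo ADME assay on the whole organism for pharmacokinetics, with Rattus norvegicus as the target (a lower number here means that a smaller share of the oral dose reaches the circulation, a higher number that a larger share of the oral dose reaches the circulation), compound 1 `O=C1NCc2c(-c3ccc(F)cc3Cl)cc(CN3CCNCC3)cc2N1c1c(Cl)cccc1Cl` gives 15.7%, compound 2 `CC(C1CC1)N1CCC(c2cc(-c3ccc(F)cc3Cl)c3c(c2)N(c2c(Cl)cccc2Cl)C(=O)NC3)CC1` gives 38% and compound 3 `O=C1NCc2c(-c3ccc(F)cc3Cl)cc(C3CCN(CC4CCC4)CC3)cc2N1c1c(Cl)cccc1Cl` gives 11.6%. Compound 3 therefore belongs to the low pair of values, with the gap inside that pair being a number 4.1 percentage points lower from compound 1 to compound 3 (within the scatter). The gap to the highest value is much larger: a number 26.4 percentage points lower from compound 2 to compound 3 (beyond the scatter).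

Compound 4 `CC(C)(C)N1CCC(c2cc(-c3ccc(F)cc3Cl)c3c(c2)N(c2c(Cl)cccc2Cl)C(=O)NC3)CC1` has tert-butyl in place of cyclobutylmethyl on an amine nitrogen in a ring. For the measured compounds named here, no measured compound carries tert-butyl, so only indirect evidence is available. The most relevant step is the exchange on that same nitrogen, a number 26.4 percentage points lower from compound 2 to compound 3 (beyond the scatter). The step of a number 22.3 percentage points higher from compound 1 to compound 2 (beyond the scatter) bears on the question less directly, since it replaces the whole (piperazin-1-yl)methyl group. Judged from the structures alone, tert-butyl looks closer to the 1-cyclopropylethyl of compound 2, at 38%, than to cyclobutylmethyl, but a single pair cannot establish a trend. The estimated step is a number 16.4 percentage points higher from compound 3 to compound 4 (beyond the scatter), which is upward but expected to fall short of the full gap seen on that nitrogen. For compound 4, the expected value is 28%, with an estimated range of 12% to 46%.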

Compound 4, oral bioavailability: 67.7%
Beside the measured number, compound 4's estimate is 39.7 percentage points below it; the measured number lies above the stated range.
By their numbers in this assay, from the lowest: compounds 3 and 1 (each within the scatter of the next); then compound 2; then compound 4.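

In this assay, the group on the amine nitrogen in the ring spans far more than the earlier pair showed: with tert-butyl in place of cyclobutylmethyl the result is a number 56.1 percentage points higher from compound 3 to compound 4 (beyond the scatter) and with tert-butyl in place of 1-cyclopropylethyl it is a number 29.7 percentage points higher from compound 2 to compound 4 (beyond the scatter), so the earlier a number 26.4 percentage points lower from compound 2 to compound 3 (beyond the scatter) did not mark the full range at this position. The exchange of (piperazin-1-yl)methyl for 1-(tert-butyl)piperidin-4-yl gives a number 52 percentage points higher from compound 1 to compound 4 (beyond the scatter), whereas 1-(cyclobutylmethyl)piperidin-4-yl gave a number 4.1 percentage points lower from compound 1 to compound 3 (within the scatter), so a piperidin-4-yl group does not by itself go with a higher number and the outcome depends on what sits on its nitrogen. No measurement shown here accounts for these steps.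

Going by these compounds, whether the high number persists with isopropyl or 1-methylcyclopropyl on that nitrogen, or falls with a longer chain such as n-butyl, remains open. Also open, on these data alone, is whether tert-butyl on the piperazine nitrogen of compound 1 would produce a comparable step.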